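This account rests on a few compounds, and the source may have more. Where it says the series, first, only, none or still open, it means among the compounds named here.

Working notes on the series. Compound 1 `CCCCCCCc1ccc2nc(N)sc2c1` and compound 2 `Nc1nc2cc(OC(F)(F)F)ccc2s1` share their core with compound 3 `CCCCn1c(=N)sc2cc(OC(F)(F)F)ccc21`. In a functional assay on the whole organism with Rattus norvegicus as the target (on this read-out lower numbers stand for an effect already at smaller amounts and higher numbers for an effect only at larger amounts of compound), compound 1 gives only a limit of the assay, > 10 mg/kg. In this assay compound 2 likewise gives only a limit of the assay, > 10 mg/kg. In this assay, going by the values given here, compound 3 gives 10 mg/kg, the only actual number among the values shown; the other two values sit at the limit of > 10 mg/kg in this assay, at which 2 of the 3 values shown sit. Among the compounds with values here, no step between measured compounds can therefore be drawn. Compound 4 `CNS(=O)(=O)CCn1c(=N)sc2cc(OC(F)(F)F)ccc21` is the next candidate: methylsulfamoyl in place of ethyl on a saturated chain carbon, two bonds along the chain from an aromatic nitrogen. The measured compounds give no indication of size or direction for this change, so no step beyond the usual scatter is assumed. In this assay the expected step is a 1.2-fold higher number from compound 3 to compound 4 (0.08 log units; within the scatter). Compound 4 is thus estimated to give 12 mg/kg in this assay, within a range of 4 mg/kg to 40 mg/kg.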

Compound 4, dose for half-maximal effect: 4 mg/kg
Beside the measured number, compound 4's estimate is 3.0-fold (0.48 log units) above it; measured number inside the range.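

The series now has its first readable step in this assay, (a 2.5-fold lower number from compound 3 to compound 4 (0.40 log units; beyond the scatter)), so this place on the chain is shown to respond to the group it carries. Methylsulfamoyl, with a hydrogen-bond donor and acceptors that ethyl lacks, is accepted here without the number moving higher. Steps to compound 1 and compound 2 cannot be read, as each of their values is a limit: the limit of > 10 mg/kg in this assay, at which 2 of the 4 values shown sit.

Whether the sulfonyl group or the hydrogen on the sulfamoyl nitrogen accounts for the step remains open. So does the effect of a carboxylic acid or an amine at this place.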